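A small ring replaces a branched chain on the sulfonyl

The compounds below may be only part of what the source reports. "The series", "measured", "known", "first", "only" and "open" are said of these compounds alone.

Measured compounds:
compound 1 `CN(c1cccc2c1CCCC2c1c[nH]cn1)S(C)(=O)=O`: 6.16
compound 2 `CC(C)S(=O)(=O)Nc1cccc2c1CCCC2c1c[nH]cn1`: 5.17

Both compounds were tested in a functional assay on Urethra for agonist activity at Alpha-1A adrenergic receptor (Oryctolagus cuniculus); on this read-out higher numbers stand for higher potency (the scale is a negative logarithm) and lower numbers for lower potency. For the measured compounds named here, compound 2 stands lower of the two numbers, and its only neighbour is compound 1, which sits clearly higher. Going by the values given here, the one measured step, a number 0.99 log units lower from compound 1 to compound 2 (beyond the scatter), exchanges a methyl(methylsulfonyl)amino group for an (isopropylsulfonyl)amino group on an aromatic carbon of the shared core.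

Compound 3 `O=S(=O)(Nc1cccc2c1CCCC2c1c[nH]cn1)C1CC1` is the next compound to be tested. It differs from compound 2 in one place: cyclopropyl in place of isopropyl on a sulfonyl sulfur. The measured step changes two things at once, the group on the sulfonamide nitrogen and the chain on the sulfonyl sulfur, so it cannot be split into a part that speaks for the sulfonyl chain alone. Among the compounds with values here, no measured pair compares an isopropyl with a cyclopropyl group. The step from compound 2 to compound 3 is therefore expected to stay within the usual scatter, a number 0.03 log units higher from compound 2 to compound 3 (within the scatter). For compound 3 the expected value in this assay is 5.2, with a range from 4.6 to 5.8.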

Compound 3, negative logarithm of the half-maximal effective concentration: 5.25
Beside the measured number, compound 3's estimate is 0.05 log units below it; low and high end bracket the measured number.
By their numbers in this assay, from the lowest: compounds 2 and 3 (each within the scatter of the next); then compound 1.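

In this assay, the exchange of isopropyl for cyclopropyl on a sulfonyl sulfur gives a number 0.08 log units higher from compound 2 to compound 3 (within the scatter), so at this position the open branched chain and the three-membered ring, each with 3 heavy atoms, cannot be told apart on this read-out. The other new step, a number 0.91 log units lower from compound 1 to compound 3 (beyond the scatter), shows that the gap to compound 1 is not particular to the isopropyl group, yet it again changes the group on the sulfonamide nitrogen and the chain on the sulfonyl sulfur together, so it cannot show which of the two accounts for the gap. No measurement at hand explains why the two chains read alike or why compound 1 stands apart.

The compounds shown leave open how a plain methyl on the sulfonyl sulfur, with hydrogen kept on the sulfonamide nitrogen, would compare, and that single comparison would separate the two changes bundled in these steps. They also leave open whether the sulfonyl position stays this even with a longer chain such as n-butyl or a larger ring such as cyclohexyl.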